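Chain lengthening on the shared core: cytotoxicity working notes

The source may report more compounds than this note shows. Statements on the series, on what has been measured and on what is new or still open speak of the compounds shown alone.

Measured in an ADME assay on THP-1 cells (Homo sapiens) for cytotoxicity, read by MTT assay, with a stated time of 11 days; a higher number here means a weaker inhibitor of growth, a lower number a stronger inhibitor of growth:
Compound 1 `CCCCCCCc1cc2c(=O)n(CC#N)cnc2s1` gives > 100 ug/mL, a limit of the assay.
Compound 2 `CCCCCc1cc2c(=O)n(CC3CC3)cnc2s1` gives > 100 ug/mL, also a limit.
Compound 3 `CCCCCCc1cc2c(=O)n(CC3CC3)cnc2s1` gives > 100 ug/mL, again a limit.

Compound 3 therefore stands only at a limit in this assay, as do the two other compounds: the limit of > 100 ug/mL in this assay, at which 3 of the 3 values shown sit. Among the compounds with values here, the one measured step that bears on the next change, a step that the two limits leave unreadable from compound 2 to compound 3, is unreadable because both ends are limits.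

Compound 4 `CCCCCCCc1cc2c(=O)n(CC3CC3)cnc2s1` differs from compound 3 by methyl in place of hydrogen on a saturated chain carbon, six bonds along the chain from an aromatic carbon. With every comparison so far ending at the limit, no step beyond the scatter can be expected, and a step that the limit leaves unreadable from compound 3 to compound 4 is the estimated step. Compound 4 is accordingly expected to give about 150 ug/mL, in a range from 60 ug/mL to 400 ug/mL, most likely reported as a limit again.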

Compound 4, concentration for 50% growth inhibition: > 100 ug/mL
Compound 4: a limit, no number; the forecaster's own chance of this, stated with the estimate: 85%; the middle value does not contradict the limit.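

No step to compound 4 can be read from compound 1, compound 2 or compound 3, since all four compounds end at a limit: the limit of > 100 ug/mL in this assay, at which 4 of the 4 values shown sit.

The compounds shown leave open whether chain length or the exchange of cyano for cyclopropyl changes growth inhibition in this assay at all.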